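Replacing 2-fluorophenyl with 4-bromophenyl on compound 1

The source may report more compounds than this note shows. Statements on the series, on what has been measured and on what is new or still open speak of the compounds shown alone.

In a functional assay on HepG2 cells (Homo sapiens) for cytotoxicity, read by MTT assay, with a stated time of 24 h (on this read-out higher numbers stand for weaker inhibition and lower numbers for stronger inhibition), compound 1 (`COc1cc(/C=C2\CN(C)C/C(=C\c3ccccc3F)C2=O)cc(OC)c1`) gives 1240 nM and sits within the scatter of compound 2 (`COc1cc(/C=C2\CN(C)C/C(=C\c3ccccc3F)C2=O)cc(OC)c1OC`) at 670 nM while compound 3 (`CN1C/C(=C\c2ccc(C(F)(F)F)cc2)C(=O)/C(=C/c2ccccc2F)C1`) reads higher at 4140 nM and lies beyond the scatter of compound 1. Compound 4 (`COc1cc(/C=C2\CN(C)C/C(=C\c3ccc(Br)cc3)C2=O)cc(OC)c1`) remains unmeasured and differs from compound 1 by 4-bromophenyl in place of 2-fluorophenyl on a double-bonded chain carbon bound to a double-bonded ring carbon on a double-bonded chain carbon bound to a double-bonded ring carbon. Going by the values given here, the only measured step, a 1.9-fold lower number from compound 1 to compound 2 (0.27 log units; within the scatter), is methoxy in place of hydrogen on an aromatic carbon and lies within the scatter. Among the compounds with values here, no measured step exchanges 2-fluorophenyl, so nothing points to a clear shift in this assay in either direction. The estimated step, a 1.2-fold higher number from compound 1 to compound 4 (0.08 log units; within the scatter), is expected to stay within the scatter. Compound 4 is expected at 1500 nM with an estimated range of 500 nM to 4500 nM in this assay.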

Compound 4, half-maximal inhibitory concentration: 4840 nM
Compound 4: middle estimate off by 3.2-fold (0.51 log units), on the low side, and the stated range ends below it.
By their numbers in this assay, from the lowest: compounds 2 and 1 (each within the scatter of the next); then compounds 3 and 4 (each within the scatter of the next).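

In this assay, the exchange of 2-fluorophenyl for 4-bromophenyl on a double-bonded chain carbon bound to a double-bonded ring carbon is a 3.9-fold higher number from compound 1 to compound 4 (0.59 log units; beyond the scatter) and is the only step shown that lies beyond the scatter. This position therefore responds to a change of its aryl group, and here the change goes toward weaker inhibition. No measured evidence accounts for this shift.

The compounds shown do not separate the loss of fluorine from the arrival of bromine or from the changed place of the halogen. They also leave open how a phenyl ring carrying an amine or a carboxylic acid would read here.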